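The compounds below may be only part of what the source reports. "The series", "measured", "known", "first", "only" and "open" are said of these compounds alone.

Of the compounds shown here, three have been measured in an assay on CHO cells for displacement of a labelled ligand from adenosine receptor A1 (Homo sapiens), read by scintillation counting, with a stated time of 60 min, tested at 10 uM; a higher number here means more inhibition at the concentration tested (going by the name of the read-out), a lower number less inhibition. Compound 1 `N=c1oc2ccc(Br)cc2cc1C(=O)NC1CCCCC1` gives 5%, the lowest of the three numbers. Compound 2 `COCCNC(=O)c1cc2cccc(OC)c2oc1=O` gives 45%, and compound 3 `COc1cccc2cc(C(=O)NCC(O)CO)c(=O)oc12` gives 14%. The gap between compound 1 and compound 3 lies within the scatter; the gap between compound 1 and compound 2 lies beyond it. Going by the values given here, the one measured step, a number 31 percentage points lower from compound 2 to compound 3 (beyond the scatter), swaps one chain for another on a different core and says nothing about ring size on the amide nitrogen.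

Compound 4 `N=c1oc2ccc(Br)cc2cc1C(=O)NC1CCCC1` differs from compound 1 in one place: cyclopentyl in place of cyclohexyl on an amide-type nitrogen. Among the compounds with values here, no measured step bears on this change, so the expectation rests on the low starting point of compound 1 alone, because 5% leaves little room for a fall and nothing here points to a rise. The step of a number 3 percentage points higher from compound 1 to compound 4 (within the scatter) is expected to stay within the scatter. Compound 4 is therefore estimated at 8%, with a range from 0% to 25%.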

Compound 4, a percentage reported as inhibition, at one concentration (the size of the read-out at that concentration, not a potency): 17%
Estimate against measurement, compound 4: 9 percentage points below; the measured number falls inside the stated range.
By their numbers in this assay, from the lowest: compounds 1, 3 and 4 (each within the scatter of the next, the first and the last beyond it); then compound 2.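

In this assay, cyclopentyl in place of cyclohexyl on an amide-type nitrogen gives a number 12 percentage points higher from compound 1 to compound 4 (beyond the scatter) on the shared core. Going by these compounds alone, this is the first sign that the group on this nitrogen can move the number on this core, since the earlier step involved chains on another core. Both groups are rings of carbon only, with no hydrogen-bond donors or acceptors, so the counted difference is the ring itself: a six-membered ring leaves and a five-membered ring enters.

Going by these compounds, with one pair, it remains open whether the number would keep rising with a still smaller ring such as cyclobutyl, or how a phenyl ring or an open butyl chain on this nitrogen would read. Nothing available here offers an explanation for this step.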